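The source may report more compounds than this note shows. Statements on the series, on what has been measured and on what is new or still open speak of the compounds shown alone.

Compound 3, with the structure `CC(C)(C)CCOc1cccc2ccc(N)nc12`, gives 201 nM in an assay on cells with melanin-concentrating hormone receptor 1 (Homo sapiens) as the target, read by radioligand binding; on this read-out higher numbers stand for weaker inhibition and lower numbers for stronger inhibition. Among the two numbers available it stands lowest; its nearest neighbour is compound 2, the structure `Nc1ccc2cccc(OCCC3CC3)c2n1`, which gives 492 nM, so that the step of a 2.4-fold lower number from compound 2 to compound 3 (0.39 log units; beyond the scatter) is modest but beyond the scatter. Compound 1, the structure `CC#CCCOc1cccc2ccc(N)nc12`, is reported only as a limit of this assay, > 2000 nM. The steps of an at least 4.0-fold lower number from compound 1 to compound 2 (0.60 log units; beyond the scatter) and an at least 9.9-fold lower number from compound 1 to compound 3 (0.99 log units; beyond the scatter) therefore rest on that limit of > 2000 nM in this assay, at which 1 of the 3 values shown sits, and give only a lower bound for their size.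

The move to compound 4, the structure `COCCOCCOc1cccc2ccc(N)nc12`, brings the change (2-methoxyethoxy in place of tert-butyl on a saturated chain carbon, two bonds along the chain from an oxygen on an aromatic ring). All three measured steps vary the group at this same place, and within them the number falls as the group goes from prop-1-yn-1-yl through cyclopropyl to tert-butyl. Among the measured compounds shown here, no measured step introduces an oxygen-bearing chain at this position, so the 2-methoxyethoxy group lies outside what the three compounds cover. Taking the spread of the measured series as a guide, a step upward in this assay of at least modest size is expected, estimated as a 7.5-fold higher number from compound 3 to compound 4 (0.87 log units; beyond the scatter). Compound 4 is accordingly expected to give about 1500 nM in this assay, within a range from 400 nM to 6000 nM.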

Compound 4, half-maximal inhibitory concentration: > 2000 nM
Compound 4 gave a limit, no number; the forecaster's own chance of this, stated with the estimate: 40%; at least 1.3-fold (0.12 log units) between middle value and limit.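

In this assay compound 4 gives > 2000 nM, which is a limit of the assay and not a number. With 2-methoxyethoxy entering in place of tert-butyl, the result is an at least 9.9-fold higher number from compound 3 to compound 4 (0.99 log units; beyond the scatter), and with the same group in place of cyclopropyl it is an at least 4.0-fold higher number from compound 2 to compound 4 (0.60 log units; beyond the scatter). This shows for the first time that a chain carrying oxygen atoms at this place, on a saturated chain carbon, two bonds along the chain from an oxygen on an aromatic ring, also reverses the gain seen with tert-butyl and cyclopropyl, so prop-1-yn-1-yl is no longer the only group that does so, while the step between compound 1 and compound 4 cannot be read and both of these compounds sit at the same limit: the limit of > 2000 nM in this assay, at which 2 of the 4 values shown sit.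

As far as these compounds go, how far compound 1 and compound 4 lie beyond that limit stays open, so the two cannot be ordered. Also open, from the compounds shown here alone, is whether a shorter methoxyethyl chain, or an amine or a carboxylic acid at the end of the chain, would stay near compound 3 or fall to the same limit.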